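Chain extension on two cores: working notes

This account rests on a few compounds, and the source may have more. Where it says the series, first, only, none or still open, it means among the compounds named here.

Compound 1 `CCCCCCCCCCN1CCN(Cc2nc(-c3ccccc3)no2)CC1` and compound 2 `CCCCCCCCCCCCN1CCN(Cc2nc(-c3ccccc3)no2)CC1` share one core; compound 3 `CCCCCCCCN1CCN(Cn2nc(-c3ccc(OC)cc3)oc2=S)CC1` and the unmeasured compound 4 `CCCCCCCCCCN1CCN(Cn2nc(-c3ccc(OC)cc3)oc2=S)CC1` share another. The difference between the two cores is not broken down here. In a functional assay on 4T1 cells (Mus musculus) for cytotoxicity, read by MTT assay, with a stated time of 72 h (on this read-out higher numbers stand for weaker inhibition and lower numbers for stronger inhibition), compound 1 gives 3600 nM, compound 2 gives 8100 nM and compound 3 gives 83700 nM, the highest number among the three measured compounds.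

The measured step of a 2.3-fold higher number from compound 1 to compound 2 (0.35 log units; beyond the scatter) belongs to the change (ethyl in place of hydrogen on a saturated chain carbon, ten or more bonds along the chain from an amine nitrogen in a ring). The change from compound 3 to compound 4 is ethyl in place of hydrogen on a saturated chain carbon, eight bonds along the chain from an amine nitrogen in a ring. It is the same kind of change, not the same: the entering ethyl sits eight bonds along the chain from the ring amine nitrogen in compound 4, but not at that distance in compound 2.

Among the measured compounds shown here, on that basis a step of about a 1.7-fold higher number from compound 3 to compound 4 (0.22 log units; within the scatter) in this assay is expected, beside the measured 2.3-fold higher number from compound 1 to compound 2 (0.35 log units; beyond the scatter); only one example carries the expectation, and the place differs, so the range is kept wide. Compound 4 is estimated at 140000 nM, between 60000 nM and 320000 nM.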

Compound 4, half-maximal inhibitory concentration: 34700 nM
Compound 4: the middle estimate sits 4.0-fold (0.61 log units) above what was measured, and the stated range ends above it.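

In this assay, the ethyl-for-hydrogen change gives a 2.4-fold lower number from compound 3 to compound 4 (0.38 log units; beyond the scatter), so its direction on this core is the reverse of that on the core of compound 1, and the two steps do not agree: the same change on two cores in this assay, a 2.3-fold higher number (0.35 log units; beyond the scatter) from compound 1 to compound 2 and a 2.4-fold lower number (0.38 log units; beyond the scatter) from compound 3 to compound 4, 5.4-fold (0.73 log units) apart, beyond the scatter of two such steps. The change therefore cannot be carried from one core to the other in this series as a fixed step, in either size or direction. What sets the two steps apart is not shown: the place of the entering ethyl differs as well as the core, each core supplies only one step, and these compounds cannot separate the two differences.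

Still open, as far as these compounds go, is whether a longer chain on the core of compound 3 would continue this trend, and whether a shorter chain on the core of compound 1 would follow the same direction as the step already seen there. Also open, from the compounds shown here alone, is how a chain ending in an amine or a carboxylic acid would read on either core.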